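Clearance notes: hydrogen for methyl on compound 2

The compounds below may be only part of what the source reports. "The series", "measured", "known", "first", "only" and "open" are said of these compounds alone.

- compound 1 `O[C@H](c1ccccn1)[C@]1(c2cccc(OC(F)(F)F)c2)C[C@@H](O)C1` gives 117 mL/min/kg
- compound 2 `C[C@]1(O)C[C@@](c2cccc(C(F)(F)F)c2)([C@H](O)c2ccccn2)C1` gives 150 mL/min/kg

Both values come from an ADME assay on liver for metabolic stability, with Liver microsome (Homo sapiens) as the target, read by LC-MS, using microsomes, with a stated time of 5 h (on this read-out higher numbers stand for fast clearance and lower numbers for slow clearance), and lie within the scatter of each other, so compound 2 stands level with compound 1 on these numbers. Going by the values given here, no measured pair differs in one place only, and the series therefore gives no direct reading of any single change.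

Compound 3 `O[C@H](c1ccccn1)[C@]1(c2cccc(C(F)(F)F)c2)C[C@@H](O)C1` is still unmeasured. It departs from compound 2 in one place: hydrogen in place of methyl on a saturated ring carbon with hydrogen in place of methyl on a saturated ring carbon. Among the compounds with values here, the data hold no measured precedent for this change, and the only anchors are compound 1 (117 mL/min/kg) and compound 2 (150 mL/min/kg). A small move toward slower clearance is expected in this assay at most, with nothing beyond the scatter. The estimated step is a 1.3-fold lower number from compound 2 to compound 3 (0.10 log units; within the scatter) and it is expected to remain within the scatter. For compound 3 the expected value is 120 mL/min/kg (estimated range 70 mL/min/kg to 190 mL/min/kg).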

Compound 3, clearance: 50 mL/min/kg
The estimate for compound 3 lay 2.4-fold (0.38 log units) above the measured number; the measured number lies below the stated range.
By their numbers in this assay, from the lowest: compound 3; then compounds 1 and 2 (each within the scatter of the next).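

In this assay, hydrogen in place of methyl on a saturated ring carbon of the four-membered non-aromatic ring of carbon only gives a 3.0-fold lower number from compound 2 to compound 3 (0.48 log units; beyond the scatter), so this ring carbon is a place where a change as small as one methyl reads beyond the scatter. Trifluoromethyl in place of trifluoromethoxy on an aromatic carbon gives a 2.3-fold lower number from compound 1 to compound 3 (0.37 log units; beyond the scatter), so the aromatic group also counts in this series, and the pair of compound 1 and compound 2, which differ in two places, could not show either step on its own. Nothing measured here accounts for either step.

Open is whether the methyl step keeps its size when trifluoromethoxy sits on the aromatic carbon, since the compounds shown give that step only with trifluoromethyl there. Also open is how this ring carbon reads with other groups in the place of the methyl, such as ethyl, fluorine or an amine, as the compounds shown hold only hydrogen and methyl there.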